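A few compounds are considered here, and "the series" means these few. Any claim that something is new, unique, unknown or untested is made for them only; others in the source may bear on it.

Within the data shown here, in a functional assay (Trachealis) for inhibition, with Cavia porcellus as the target (a lower number here means a stronger inhibitor, a higher number a weaker inhibitor), compound 2 `CC1(C)C=C(n2cccc2)c2cc(C#N)ccc2O1` gives 4080 nM, the highest of the three numbers measured so far. Compound 1 `CC1(C)C=C(n2cccc2[N+](=O)[O-])c2cc(C#N)ccc2O1` gives 690 nM and compound 3 `CC1(C)C=C(n2ccc(C#N)c2)c2cc(C#N)ccc2O1` gives 2400 nM. Compound 4 `CC1(C)C=C(n2cccc2C(=O)C(F)(F)F)c2cc(C#N)ccc2O1` is not yet measured; compared with compound 2 it carries (trifluoromethyl)carbonyl in place of hydrogen on an aromatic carbon. Among the measured compounds shown here, two measured steps bear on this. Going from compound 1 to compound 2 gave a 5.9-fold higher number from compound 1 to compound 2 (0.77 log units; beyond the scatter), so removing the nitro from the aromatic carbon next to the ring nitrogen weakened inhibition. Going from compound 2 to compound 3 gave a 1.7-fold lower number from compound 2 to compound 3 (0.23 log units; within the scatter), a change at a different place. Placing a new group on the aromatic carbon next to the ring nitrogen is therefore expected to lower the number, with a step of about a 4.1-fold lower number from compound 2 to compound 4 (0.61 log units; beyond the scatter). Compound 4 is estimated at 1000 nM, within a range from 400 nM to 2500 nM.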

Compound 4, half-maximal inhibitory concentration: 690 nM
The estimate for compound 4 lay 1.4-fold (0.16 log units) above the measured number; the measured number falls inside the stated range.
By their numbers in this assay, from the lowest: compounds 1 and 4 (each within the scatter of the next); then compounds 3 and 2 (each within the scatter of the next).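

In this assay, (trifluoromethyl)carbonyl on the aromatic carbon next to the ring nitrogen gave a 5.9-fold lower number from compound 2 to compound 4 (0.77 log units; beyond the scatter) and so lowers the number as nitro does. Exchanging nitro for this group gave no change at the digits printed from compound 1 to compound 4 (within the scatter) and shows that the gain at this carbon is not tied to nitro alone. No measurement here explains why the two groups match.

Going by these compounds, whether an amine or a carboxylic acid on this carbon would also lower the number remains open. So does whether (trifluoromethyl)carbonyl would do the same at the place where compound 3 carries its cyano.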